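The source may report more compounds than this note shows. Statements on the series, on what has been measured and on what is new or still open speak of the compounds shown alone.

Compound 1 `COc1ccccc1NC(=S)N/N=C/c1ccc2ccccc2n1` is a thiosemicarbazone built on a quinoline-type aldehyde, carrying a 2-methoxyphenyl group on the amide-type nitrogen. In a functional assay on HL-60 cells (Homo sapiens) for antiproliferative activity, read by sulforhodamine B assay, with a stated time of 72 h (a higher number here means a weaker inhibitor, a lower number a stronger inhibitor), compound 1 gives 91700 nM, which is the highest of the two numbers recorded here, so it is the weakest of the two inhibitors that gave a number. Its closest neighbour is compound 2 `S=C(NCc1ccccc1)N/N=C/c1ccc2ccccc2n1`, in which a benzyl group takes the place of the 2-methoxyphenyl; in this assay compound 2 gives 21900 nM, so the swap gave a 4.2-fold lower number from compound 1 to compound 2 (0.62 log units; beyond the scatter). Compound 3 `NC(=S)N/N=C/c1nc2ccccc2s1` carries no substituent on that nitrogen and sits on a different core; in this assay compound 3 reaches only the limit > 100000 nM, a boundary of the assay rather than a number, as noted in the limit of > 100000 nM in this assay, at which 1 of the 3 values shown sits.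

The next compound, compound 4 `NC(=S)N/N=C/c1ccc2ccccc2n1`, keeps the core of compound 1 and strips the nitrogen bare: hydrogen in place of 2-methoxyphenyl on an amide-type nitrogen. Among the measured compounds shown here, only the step from compound 1 to compound 2 bears on it, and it shows that a change at this nitrogen can move the number modestly. Since compound 3, also bare at this nitrogen, gave only a limit, the expected shift from compound 1 to compound 4 in this assay is a 1.3-fold lower number from compound 1 to compound 4 (0.12 log units; within the scatter). Compound 4 is therefore estimated at 70000 nM, within a range from 15000 nM to 250000 nM.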

Compound 4, half-maximal inhibitory concentration: > 100000 nM
Compound 4: no number, only a limit (the forecaster's own chance of this, stated with the estimate: 40%); middle value at least 1.4-fold (0.15 log units) from the limit.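

In this assay compound 4 gives > 100000 nM, which is a limit of the assay and not a number, and the bare nitrogen puts it among the compounds at that limit: the limit of > 100000 nM in this assay, at which 2 of the 4 values shown sit.

Set against the benzyl group, the change can be read clearly, as hydrogen on this amide-type nitrogen gives an at least 4.5-fold higher number from compound 2 to compound 4 (0.65 log units; beyond the scatter), so on the shared core the benzyl compound is the stronger inhibitor of the pair. Set against the 2-methoxyphenyl group, the change stays unsettled: the step is an at least 1.0-fold higher number from compound 1 to compound 4 (0.03 log units; that floor lies within the scatter), and because that is only a floor, compound 1 may or may not hold a real edge over the bare nitrogen.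

This leaves open whether the gain belongs to benzyl specifically or would appear with other groups on this nitrogen, such as a plain phenyl, a methyl or a longer chain like phenethyl. A phenyl without the methoxy would be especially telling, as would any pair that gives two true numbers rather than a limit, since only such a pair could size the effect of this nitrogen's substituent.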